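Aryl-to-aryloxy swap at the para position of the core

The source may report more compounds than this note shows. Statements on the series, on what has been measured and on what is new or still open speak of the compounds shown alone.

Measured so far in an assay on isolated protein for agonist activity at Bile acid receptor (Homo sapiens), read by AlphaScreen, with a stated time of 30 min; a higher number here means that more compound is needed for the effect, a lower number that less compound is needed:
- compound 1 `CCOc1cccc(-c2ccc([C@H]3S[C@@H](C)C(=O)Nc4c3c(C)nn4-c3ccccc3C)cc2)c1` gives 3500 nM
- compound 2 `Cc1ccc(-n2nc(C)c3c2NC(=O)[C@H](C)S[C@@H]3c2ccc(Oc3ccccc3)cc2)cc1` gives 3400 nM
- compound 3 `Cc1cccc(-n2nc(C)c3c2NC(=O)[C@H](C)S[C@@H]3c2ccc(Oc3ccccc3)cc2)c1` gives 2400 nM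

Compound 1 gives the highest of the three numbers, but its gap to compound 2 and to compound 3 lies within the scatter, so no order among them can be read. Going by the values given here, the one single-point step, a 1.4-fold lower number from compound 2 to compound 3 (0.15 log units; within the scatter), is also within the scatter.

Compound 4 `COc1cccc(Oc2ccc([C@H]3S[C@@H](C)C(=O)Nc4c3c(C)nn4-c3ccccc3C)cc2)c1` differs from compound 1 by 3-methoxyphenoxy in place of 3-ethoxyphenyl on an aromatic carbon. Among the compounds with values here, no measured step covers this change directly. Compound 2 carries a phenoxy group at the same place and gives a number within the scatter of compound 1, which suggests the ether linkage is tolerated. Compound 4 is therefore expected at about 3000 nM (range 1200 nM to 8000 nM), a step of a 1.2-fold lower number from compound 1 to compound 4 (0.07 log units; within the scatter), within the scatter.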

Compound 4, half-maximal effective concentration: 1700 nM
For compound 4 the middle estimate is 1.8-fold (0.25 log units) above the measured one; measured number inside the range.
By their numbers in this assay, from the lowest: compounds 4, 3, 2 and 1 (each within the scatter of the next, the first and the last beyond it).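

In this assay, going by these compounds alone, the swap of 3-ethoxyphenyl for 3-methoxyphenoxy gives a 2.1-fold lower number from compound 1 to compound 4 (0.31 log units; beyond the scatter) as the only step beyond the scatter, showing that this place, para to a large group, responds to a change in its substituent. The swap alters the linkage and the alkoxy chain together, while the heavy-atom count stays the same. Nothing at hand bears on the cause of this step. Which of the two alterations carries the step stays open. Also open, on these data alone, is how an amine or a carboxylic acid on that ring would read.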